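Replacing a Carboxyethenyl Amide with a Chloropyridinyl Amide

The compounds below may be only part of what the source reports. "The series", "measured", "known", "first", "only" and "open" are said of these compounds alone.

Measured compounds:
- Compound 1, `O=C(Nc1ccc(Cl)cc1)c1cc([N+](=O)[O-])ccc1Cl`: > 25000 nM
- Compound 2, `O=C(O)/C=C/C(=O)Nc1cccc(-c2nc3ccccc3s2)c1`: > 25000 nM

In an ADME assay on Raji cells (Homo sapiens) for inhibition, with a stated time of 72 h (on this read-out higher numbers stand for an effect only at larger amounts of compound and lower numbers for an effect already at smaller amounts), compound 2 gives only a limit, > 25000 nM, and not a number. Compound 1 likewise gives only a limit in this assay, > 25000 nM. Within the data shown here, both measured values thus sit at the same place, (the limit of > 25000 nM in this assay, at which 2 of the 2 values shown sit), so compound 2 stands at the limit together with the one other compound measured, and no ordering between them can be read from the data.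

Compound 3, `O=C(Nc1cccc(-c2nc3ccccc3s2)c1)c1cccnc1Cl`, has not yet been measured. It differs from compound 2 in one place: 2-chloropyridin-3-yl in place of 2-carboxyethenyl on a carbonyl carbon. Among the measured compounds shown here, since both measured compounds show only a limit, no measured step exists to calibrate this change. The step of an at least 1.2-fold lower number from compound 2 to compound 3 (0.09 log units; that floor lies within the scatter) is expected to be none beyond the scatter, with the outcome most likely remaining a limit. Compound 3 is therefore estimated at 20000 nM, with a range from 4000 nM to 40000 nM, because compound 2 already sits at the limit > 25000 nM in this assay.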

Compound 3, half-maximal effective concentration: > 25000 nM
Compound 3: only a limit was reported; the forecaster's own chance of this, stated with the estimate: 60%; at least 1.2-fold (0.09 log units) between middle value and limit.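

In this assay compound 3 gives > 25000 nM as a limit and not a number. Among these compounds, compound 2 likewise gives > 25000 nM as a limit, so no step from compound 2 to compound 3 can be read: the limit of > 25000 nM in this assay, at which 3 of the 3 values shown sit. The compounds shown leave open how 2-chloropyridin-3-yl and 2-carboxyethenyl on a carbonyl carbon compare in this assay as actual numbers.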